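A few compounds are considered here, and "the series" means these few. Any claim that something is new, unique, unknown or untested is made for them only; others in the source may bear on it.

Three compounds that share one core were measured in an ADME assay on cells (Epithelial cell, Homo sapiens) for cytotoxicity, read by MTT assay; a higher number here means that more compound is needed for the effect, a lower number that less compound is needed. Compound 1 `CCCCCCCCCCCCCCCCCCCCCCOC(=O)NC(CCC(=O)O)(CCC(=O)O)CCC(=O)O` gives 360000 nM, and compound 2 `CCCCCCCCCCCCCCCCCCOC(=O)NC(CCC(=O)O)(CCC(=O)O)CCC(=O)O` gives 350000 nM. Going by the values given here, the only step between measured compounds that differ in a single place is a 1.0-fold lower number from compound 1 to compound 2 (0.01 log units; within the scatter), a change in the length of the long saturated chain that leaves the read-out unmoved. Compound 3 `CCCCCCCCCCCCCCCCCCCCNC(=O)NC(CCC(=O)O)(CCC(=O)O)CCC(=O)O` gives 210000 nM, a number that sits within the usual scatter of both compound 1 and compound 2, so the three compounds cannot be told apart on these figures.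

Compound 4 `CCCCCCCCCCCCCCCCCCCCCCNC(=O)NC(CCC(=O)O)(CCC(=O)O)CCC(=O)O` differs from compound 3 by ethyl in place of hydrogen on a saturated chain carbon, ten or more bonds along the chain from an amide-type nitrogen. Among the compounds with values here, the one step that bears on it is a 1.0-fold lower number from compound 1 to compound 2 (0.01 log units; within the scatter), a larger change of the same chain in the other pair, and it lay within the scatter. The step from compound 3 to compound 4 is therefore expected to be a 1.1-fold higher number from compound 3 to compound 4 (0.04 log units; within the scatter), that is, no movement beyond the scatter in either direction. Compound 4 is accordingly estimated to give about 230000 nM in this assay, with a range from 110000 nM to 460000 nM.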

Compound 4, half-maximal effective concentration: 260000 nM
For compound 4 the middle estimate is 1.1-fold (0.05 log units) below the measured one; low and high end bracket the measured number.
By their numbers in this assay, from the lowest: compounds 3, 4, 2 and 1 (each within the scatter of the next).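

In this assay, ethyl in place of hydrogen on a saturated chain carbon, ten or more bonds along the chain from an amide-type nitrogen, gives a 1.2-fold higher number from compound 3 to compound 4 (0.09 log units; within the scatter). Going by these compounds alone, a change in chain length at this far end therefore stays within the scatter with the amide-type nitrogen as well, whereas the earlier compounds offered only a 1.0-fold lower number from compound 1 to compound 2 (0.01 log units; within the scatter), a step in the chain attached through an oxygen next to a carbonyl group. Nothing available explains why the read-out barely responds to these changes in the long chain.

The compounds shown cover only long saturated chains, so it remains open whether a much shorter chain such as hexyl, or a long chain ending in a carboxylic acid or an amine, would take the number beyond the scatter. Also open, from the compounds shown here alone, is what would happen if a phenyl ring were placed in the chain, or if methyl esters stood in place of the three carboxylic acid groups on the shared core.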